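Cyclopentyl to 3-hydroxypropyl: working notes

A few compounds are considered here, and "the series" means these few. Any claim that something is new, unique, unknown or untested is made for them only; others in the source may bear on it.

Measured in a functional assay on KBVIN cells (Homo sapiens) for antiproliferative activity, read by sulforhodamine B assay, with a stated time of 48 h; a higher number here means a weaker inhibitor of growth, a lower number a stronger inhibitor of growth:
- Compound 1 `COc1ccc(Nc2nc(NC3CCCC3)c3ccccc3n2)cc1` gives 12600 nM
- Compound 2 `Nc1ccc(Nc2nc(NC3CCCC3)c3ccccc3n2)cc1` gives 21700 nM

Among the compounds with values here, compound 2 stands at 21700 nM, and compound 1 is its only comparison: a 1.7-fold higher number from compound 1 to compound 2 (0.24 log units; within the scatter). These two values therefore set no order.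

Compound 3 `Nc1ccc(Nc2nc(NCCCO)c3ccccc3n2)cc1` keeps the amino group of compound 2 and carries 3-hydroxypropyl in place of cyclopentyl on a nitrogen on an aromatic ring. The same difference reads cyclopentylamino to (3-hydroxypropyl)amino.

Within the data shown here, only one measured step is available, a 1.7-fold higher number from compound 1 to compound 2 (0.24 log units; within the scatter). It is amino in place of methoxy on an aromatic carbon, a different change at a different place, so it bears on this one only weakly. Among the measured compounds shown here, no measured step touches the cyclopentyl group. In this assay, a small move towards a higher number is expected, though not one clearly beyond the scatter, and the uncertainty is wide. The estimate means an expected 1.5-fold higher number from compound 2 to compound 3 (0.17 log units; within the scatter). For compound 3 the expected value is 32000 nM, with an estimated range of 11000 nM to 80000 nM.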

Compound 3, concentration for 50% growth inhibition in the KBVIN assay: 18700 nM
Estimate against measurement, compound 3: 1.7-fold (0.23 log units) above; the measured number falls inside the stated range.
By their numbers in the KBVIN assay, from the lowest: compounds 1, 3 and 2 (each within the scatter of the next).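

Within the data shown here, in the KBVIN assay, compound 2 gives 21700 nM and compound 3 gives 18700 nM; the first measured change at this nitrogen gives a 1.2-fold lower number from compound 2 to compound 3 (0.06 log units; within the scatter), so the two groups are not told apart here. With the amino group held constant, the cyclopentyl ring, with no hydrogen-bond donor or acceptor, gives way to the open 3-hydroxypropyl chain, which has one of each, and the number stays within the scatter; the earlier step, which concerned only the group on the aromatic carbon, could not show this. In a physicochemical assay for lipophilicity, read by HPLC, measured as octanol-water partition, with a stated time of 24 h (a lower number here means a more polar compound, a higher number a more lipophilic compound), compound 2 gives "not determined" (no result reported) and compound 3 gives "not determined" (no result reported), so the same step cannot be read there. Nothing available accounts for the result in either direction.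

As far as these compounds go, it remains open whether a longer chain, or an amine or a carboxylic acid in place of the hydroxy group, would also stay within the scatter of compound 3 in the KBVIN assay, or whether this position responds only to larger departures from these two groups. Also open, from the compounds shown here alone, is whether 3-hydroxypropyl in place of cyclopentyl reads the same when methoxy, as in compound 1, stands in place of the amino group.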